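The source may report more compounds than this note shows. Statements on the series, on what has been measured and on what is new or still open speak of the compounds shown alone.

Measured compounds in an ADME assay on stomach for pharmacokinetics, in simulated gastric fluid; on this read-out higher numbers stand for a longer-lived compound and lower numbers for a shorter-lived compound:
Compound 1, `CCOc1cc(NC(=O)C2(NC(=O)c3ccc4c(C5CCCC5)c(-c5ncc(Cl)cn5)n(C)c4c3)CCC2)ccc1/C=C/C(=O)N[C@@H](CCC(=O)O)C(N)=O` — 0.533 h
Compound 2, `CCOc1cc(NC(=O)C2(NC(=O)c3ccc4c(C5CCCC5)c(-c5ncc(Cl)cn5)n(C)c4c3)CCC2)ccc1/C=C/C(=O)N[C@@H](CCCNC(=N)N)C(N)=O` — 0.467 h
Compound 3, `CCOC(=O)/C=C/c1ccc(NC(=O)C2(NC(=O)c3ccc4c(C5CCCC5)c(-c5ncc(Cl)cn5)n(C)c4c3)CCC2)cc1OCC` — 0.333 h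

Compound 3 sits within the scatter of both of its neighbours: the step is a 1.6-fold lower number from compound 1 to compound 3 (0.20 log units; within the scatter) and a 1.4-fold lower number from compound 2 to compound 3 (0.15 log units; within the scatter), so the three numbers cannot be ranked against one another. The third recorded step, a 1.1-fold lower number from compound 1 to compound 2 (0.06 log units; within the scatter), is likewise within the scatter.

Compound 4, `CCCCCCOC(=O)/C=C/c1ccc(NC(=O)C2(NC(=O)c3ccc4c(C5CCCC5)c(-c5ncc(Cl)cn5)n(C)c4c3)CCC2)cc1OCC`, is the compound still to be measured. Its change from compound 3 is butyl in place of hydrogen on a saturated chain carbon, two bonds along the chain from an oxygen next to a carbonyl group. None of the three measured steps touches this part of the molecule; the steps from compound 1 and compound 2 to compound 3 replace the whole group on the carbonyl carbon, and the step from compound 1 to compound 2 alters the far end of that group. For the measured compounds named here, every recorded step stayed within the scatter, and no step here shows the effect of lengthening the chain beyond the oxygen next to the carbonyl group. Compound 4 is therefore expected to show a step of a 1.0-fold lower number from compound 3 to compound 4 (0.00 log units; within the scatter), nothing beyond the scatter. For compound 4 the estimate in this assay is 0.33 h, within a range of 0.17 h to 0.67 h.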

Compound 4, half-life: 0.883 h
Estimate against measurement, compound 4: 2.7-fold (0.43 log units) below; measured number above the stated range.
By their numbers in this assay, from the lowest: compounds 3, 2, 1 and 4 (each within the scatter of the next, the first and the last beyond it).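

In this assay, for the compounds shown here, the change from ethoxy to hexyloxy on the carbonyl carbon gives a 2.7-fold higher number from compound 3 to compound 4 (0.42 log units; beyond the scatter), the only step in this set that lies beyond the scatter, so the length of the chain at this position can register on this read-out, which none of the earlier steps showed. The hexyloxy group on the carbonyl carbon does not separate from the two larger amino groups there, with a 1.9-fold higher number from compound 2 to compound 4 (0.28 log units; within the scatter) and a 1.7-fold higher number from compound 1 to compound 4 (0.22 log units; within the scatter). No evidence at hand bears on what lies behind the step from ethoxy to hexyloxy.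

The compounds shown leave open how a butoxy chain between these two lengths, or a longer chain such as octyloxy, would read at this position. They also leave open how a branched isopropoxy group or a hexyl chain ending in an amine would read there.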